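The source may report more compounds than this note shows. Statements on the series, on what has been measured and on what is new or still open speak of the compounds shown alone.

Measured so far:
compound 1 `CCOC(=O)c1sc(-c2cccc(NC(=O)c3ccc(C(C)(C)C)cc3)c2)nc1Nc1ccc(N2CCN(C)CC2)cc1`: 4.22%
compound 2 `CCOC(=O)c1sc(-c2cccc(NC(=O)c3ccc(C(F)(F)F)cn3)c2)nc1Nc1ccc(N2CCN(C)CC2)cc1`: 20.8%
compound 3 `CN1CCN(c2ccc(Nc3nc(-c4cccc(NC(=O)c5ccc(C(C)(C)C)cc5)c4)sc3C(N)=O)cc2)CC1`: 12.1%

In a functional assay on Raji cells (Homo sapiens) for antiproliferative activity, read by CCK-8 assay, with a stated time of 72 h, tested at 40 uM (on this read-out lower numbers stand for less inhibition and higher numbers for more inhibition at the one concentration tested (going by the name of the read-out)), compound 3 stands second highest of the three numbers. The gap is small (a number 7.9 percentage points higher from compound 1 to compound 3 (within the scatter)), and the value of compound 2 also lies within the usual scatter of that of compound 3, so no order among the three can be read.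

Compound 4 `CN1CCN(c2ccc(Nc3nc(-c4cccc(NC(=O)c5ccco5)c4)sc3C(N)=O)cc2)CC1` carries the change (furan-2-yl in place of 4-(tert-butyl)phenyl on a carbonyl carbon).

Among the compounds with values here, the only measured step at this carbonyl carbon is a number 16.6 percentage points higher from compound 1 to compound 2 (beyond the scatter), where the same 4-(tert-butyl)phenyl group was replaced by another ring on the ethoxy-bearing core. On the amino-bearing core, the change to furan-2-yl is expected to give a step in the same direction, at or near the scatter, estimated as a number 5.9 percentage points higher from compound 3 to compound 4 (within the scatter). Compound 4 is therefore estimated at 18%, within 5% to 35%.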

Compound 4, a percentage reported as inhibition, at one concentration (the size of the read-out at that concentration, not a potency): 84.3%
Compound 4: the middle estimate sits 66.3 percentage points below what was measured; the measured number lies above the stated range.
By their numbers in this assay, from the lowest: compounds 1, 3 and 2 (each within the scatter of the next, the first and the last beyond it); then compound 4.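

In this assay, furan-2-yl in place of 4-(tert-butyl)phenyl on the carbonyl carbon gives a number 72.2 percentage points higher from compound 3 to compound 4 (beyond the scatter) and so is a large step. The group at this place can therefore move the read-out much further than a number 16.6 percentage points higher from compound 1 to compound 2 (beyond the scatter) on the ethoxy-bearing core had shown. No available evidence accounts for this step.

Still open, going by these compounds, is whether furan-2-yl gives a similar step with ethoxy on the other carbonyl carbon, as in compound 1. Also open, on these data alone, is whether thiophen-2-yl or unsubstituted phenyl at this place keeps the level of compound 4.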